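The source may hold more compounds than are shown below. What is called first, only, known or untested is meant among the compounds shown, and "the series" means these compounds.

Measured so far:
- compound 1 `COc1cc(C)cc(-c2c(-c3ccnc(-c4ccc(C(C)=O)cc4)c3)cnn2CC#N)c1`: 78%
- compound 2 `COc1cc(C)cc(-c2nn(CC#N)cc2-c2ccc(-c3cccc(C(C)=O)c3)nc2)c1`: 79%

In a functional assay on UO-31 cells (Homo sapiens) for cytotoxicity, read by sulforhodamine B assay, with a stated time of 48 h, tested at 100 nM (a lower number here means a stronger effect, a higher number a weaker effect of the compound at the concentration tested), compound 1 gives 78%. In this assay compound 2 gives 79%, and the two numbers sit within the scatter of each other, so nothing separates them. The two structures differ in more than one place, and no single step can be read from them.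

Compound 3 `COc1cc(C)cc(-c2c(-c3ccnc(-c4ccc(N(C)C)cc4)c3)cnn2CC#N)c1` differs from compound 1 in one place: dimethylamino in place of acetyl on an aromatic carbon. Going by the values given here, no measured step in this assay bears on this exchange, so no step beyond the scatter is expected. Compound 3 is estimated at 76%, between 55% and 95%. The expected step of a number 2 percentage points lower from compound 1 to compound 3 (within the scatter) stays within the scatter.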

Compound 3, a percentage reported as activity, at one concentration (the size of the read-out at that concentration, not a potency): 45%
Beside the measured number, compound 3's estimate is 31 percentage points above it, and the stated range ends above it.
By their numbers in this assay, from the lowest: compound 3; then compounds 1 and 2 (each within the scatter of the next).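

In this assay, going by these compounds alone, the group on the 4-acetylphenyl ring is not indifferent: dimethylamino in place of acetyl gives a number 33 percentage points lower from compound 1 to compound 3 (beyond the scatter) and is the first step beyond the scatter. Acetyl and dimethylamino have the same count of heavy atoms and hydrogen-bond acceptors, so those counts do not separate them. Nothing measured here accounts for the step. Still open, as far as these compounds go, is whether a primary amine or a methoxy group at this place reads like dimethylamino or like acetyl. Also open, from the compounds shown here alone, is whether dimethylamino gives a similar step on the core of compound 2.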